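Chain Extension in a Carbamate Tricarboxylic Acid Series

A few compounds are considered here, and "the series" means these few. Any claim that something is new, unique, unknown or untested is made for them only; others in the source may bear on it.

Measured compounds:
Compound 1, `CCCCCCCCCCCCCCCCOC(=O)NC(CCC(=O)O)(CCC(=O)O)CCC(=O)O`, gives 440000 nM in an ADME assay on cells (Epithelial cell, Homo sapiens) for cytotoxicity, read by MTT assay; a higher number here means that more compound is needed for the effect, a lower number that less compound is needed.
Compound 2, `CCCCCCCCCCCCCCCCCCCCNC(=O)NC(CCC(=O)O)(CCC(=O)O)CCC(=O)O`, gives 210000 nM in this assay.

Compound 1 holds the highest of the two numbers seen so far. Its nearest neighbour on the scale is compound 2, which carries a longer saturated chain joined through a urea rather than a carbamate, and the gap between the two values lies beyond the scatter of repeated measurements, so compound 2 is read as needing less compound for the same effect.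

The unmeasured compound 3, `CCCCCCCCCCCCCCCCCCCCOC(=O)NC(CCC(=O)O)(CCC(=O)O)CCC(=O)O`, keeps the carbamate linkage of compound 1 but carries the longer chain of compound 2. The change from compound 1 is butyl in place of hydrogen on a saturated chain carbon, ten or more bonds along the chain from an oxygen next to a carbonyl group. Among the compounds with values here, no step between measured compounds isolates this change on its own, so the direction is inferred from what compound 1 and compound 2 show: the longer-chain compound gives the lower number. A modest drop is therefore expected, near the edge of the scatter. The expected step of a 1.7-fold lower number from compound 1 to compound 3 (0.23 log units; within the scatter) puts compound 3 at an estimated 260000 nM, with a range of 120000 nM to 520000 nM.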

Compound 3, half-maximal effective concentration: 280000 nM
Estimate against measurement, compound 3: 1.1-fold (0.03 log units) below, and the stated range covers the measured number.
By their numbers in this assay, from the lowest: compounds 2, 3 and 1 (each within the scatter of the next, the first and the last beyond it).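

With the carbamate kept, butyl in place of hydrogen on a saturated chain carbon, ten or more bonds along the chain from an oxygen next to a carbonyl group, gives a 1.6-fold lower number from compound 1 to compound 3 (0.20 log units; within the scatter) in this assay, so this change alone does not stand clear of the scatter. Within the data shown here, compound 3 also gives the first view of the carbamate and the urea on the same chain: compound 3 gives 280000 nM and compound 2 gives 210000 nM, and these two values lie within the scatter of each other, so the gap beyond the scatter between compound 1 and compound 2 is seen only with both differences together. Nothing measured here explains where any of these numbers falls.

The compounds shown leave open how a shorter chain, or a chain carrying a phenyl ring, would read in this assay. They also leave open what an amide in place of the carbamate or urea would give, and what would follow if a methyl ester replaced a carboxylic acid on the shared core.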